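This account rests on a few compounds, and the source may have more. Where it says the series, first, only, none or still open, it means among the compounds named here.

In a functional assay on A549 cells (Homo sapiens) for cytotoxicity (on this read-out lower numbers stand for an effect already at smaller amounts and higher numbers for an effect only at larger amounts of compound), compound 1 `c1ccc(COc2cc(-c3ccccc3)nc3ccccc23)cc1` gives > 10 ug/mL, which is a limit of the assay and not a number. Compound 2 `Oc1ccc2c(O)cc(-c3ccccc3)nc2c1` gives 0.81 ug/mL and compound 3 `Oc1cc(-c2ccccc2)nc2cc(F)ccc12` gives 0.96 ug/mL. Compound 4 `CC(C)COc1cc(-c2ccccc2)nc2ccccc12` keeps the core of compound 1 but turns benzyloxy into isobutoxy, which places isopropyl in place of phenyl on a saturated chain carbon bound to an oxygen on an aromatic ring. Within the data shown here, the only measured step is a 1.2-fold higher number from compound 2 to compound 3 (0.07 log units; within the scatter), fluoro in place of hydroxy on an aromatic carbon. It lies within the scatter and does not involve the group that changes here, so it gives only weak guidance. No step beyond the scatter is therefore expected in this assay, in either direction, and compound 4 will probably stay near the limit of compound 1. The expected step is a step that the limit leaves unreadable from compound 1 to compound 4. For compound 4 the estimated value is 14 ug/mL, with an expected range from 5 ug/mL to 40 ug/mL.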

Compound 4, half-maximal effective concentration: > 10 ug/mL
Compound 4: a limit, no number (the forecaster's own chance of this, stated with the estimate: 65%); the middle value is on the limit's open side.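

Compound 1 and compound 4 both stop at a limit of the assay rather than giving a number, so no step between them can be read: the limit of > 10 ug/mL in this assay, at which 2 of the 4 values shown sit.

The compounds shown leave open whether isobutoxy in place of benzyloxy changes the cytotoxic effect at all.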